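Chloro to Bromo: One Halogen Swap on Compound 1

The source may hold more compounds than are shown below. What is called first, only, known or untested is meant among the compounds shown, and "the series" means these compounds.

Compound 1 `O=C(Nc1sc2c(c1C(=O)NNc1ccc(Cl)cc1)CCCCC2)NS(=O)(=O)c1ccccc1` gives 2900 nM in a functional assay on HCC 2998 cells (Homo sapiens) for inhibition, with a stated time of 48 h; a lower number here means a stronger inhibitor of growth, a higher number a weaker inhibitor of growth.
Compound 2 `CCCNC(=O)c1c(NC(=O)NS(=O)(=O)c2ccccc2)sc2c1CCCCC2` reaches only the assay limit > 100000 nM in this assay; this is a limit, not a number.

Among the measured compounds shown here, compound 1 therefore stands as the only measured number in this assay; the second value is a limit. For the measured compounds named here, the single measured step, an at least 34-fold higher number from compound 1 to compound 2 (1.53 log units; beyond the scatter), exchanges propyl for (4-chlorophenyl)amino on an amide-type nitrogen, and its size can only be stated as a bound because of the limit of > 100000 nM in this assay, at which 1 of the 2 values shown sits. Going by the values given here, that step touches a different part of the molecule from the one altered in compound 3 `O=C(Nc1sc2c(c1C(=O)NNc1ccc(Br)cc1)CCCCC2)NS(=O)(=O)c1ccccc1`, which differs from compound 1 by bromo in place of chloro on an aromatic carbon. Among the compounds with values here, no measured step exchanges one halogen for another, so the one step on record does not bear directly on this change, and nothing here suggests a move beyond the scatter in either direction. Compound 3 is accordingly expected to show about 2600 nM in this assay, within a range of 1000 nM to 7000 nM. The expected step is a 1.1-fold lower number from compound 1 to compound 3 (0.05 log units; within the scatter).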

Compound 3, concentration for 50% growth inhibition: 1600 nM
Compound 3: the middle estimate sits 1.6-fold (0.21 log units) above what was measured, within the range that was stated.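

Compound 3 supplies the only step shown at the aromatic carbon para to a large group, and in this assay the exchange of chloro for bromo gives a 1.8-fold lower number from compound 1 to compound 3 (0.26 log units; within the scatter), so the two halogens cannot be told apart here. Set against propyl on the amide-type nitrogen, (4-bromophenyl)amino gives an at least 62-fold lower number from compound 2 to compound 3 (1.79 log units; beyond the scatter), which places a second halogen-bearing arylamino group on the same side of compound 2 as the (4-chlorophenyl)amino group of compound 1. The size of that step can be stated only as a bound because the entry for compound 2 is a limit and not a number: the limit of > 100000 nM in this assay, at which 1 of the 3 values shown sits.

What the compounds shown leave open is whether a halogen is needed at this position at all, as the effect of a plain phenyl ring, a methoxy group or a nitrile there cannot be judged from them. As far as these compounds go, it also remains open whether the large step away from propyl depends on the aromatic ring or on the second nitrogen, a question that a benzyl group on the amide-type nitrogen would address.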